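A few compounds are considered here, and "the series" means these few. Any claim that something is new, unique, unknown or untested is made for them only; others in the source may bear on it.

Among the compounds with values here, compound 1 `O=C(Nc1ccc(Cl)c(-c2nnc3c(Cl)cccn23)c1)c1cccc(Cl)c1` is the only member of this set with a number in a functional assay on MDA-MB-231 cells (Homo sapiens) for antiproliferative activity, read by MTT assay, with stated times of 72 h and 4 h; a lower number here means a stronger inhibitor, a higher number a weaker inhibitor: compound 1 gives 66100 nM. Compound 2 `O=C(Nc1ccc(Cl)c(-c2nnc3c(Cl)cccn23)c1)c1ccon1` reaches only the limit of this assay, with compound 2 reported as > 100000 nM. Compound 3 `O=C(Nc1ccc(Cl)c(-c2nnc3c(Cl)cccn23)c1)c1c(F)cccc1Cl` likewise stops at the limit, compound 3 being reported as > 100000 nM. Both steps away from compound 1 weaken the inhibitor, an at least 1.5-fold higher number from compound 1 to compound 2 (0.17 log units; that floor lies within the scatter) and an at least 1.5-fold higher number from compound 1 to compound 3 (0.17 log units; that floor lies within the scatter), each running into (the limit of > 100000 nM in this assay, at which 2 of the 3 values shown sit). Compound 4 `O=C(Nc1ccc(Cl)c(-c2nnc3c(Cl)cccn23)c1)c1ccccc1` differs from compound 1 by hydrogen in place of chloro on an aromatic carbon. Within the data shown here, no measured step removes a single substituent from the acyl ring, so the measured steps give only a direction. A number near the limit is expected for compound 4, at 90000 nM within 40000 nM to 200000 nM. That means an expected step of a 1.4-fold higher number from compound 1 to compound 4 (0.13 log units; within the scatter), within the scatter.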

Compound 4, half-maximal inhibitory concentration: 58200 nM
Compound 4: middle estimate off by 1.5-fold (0.19 log units), on the high side; the measured number falls inside the stated range.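

In this assay, replacing the chloro of the 3-chlorophenyl group with hydrogen leaves the number essentially unchanged, a 1.1-fold lower number from compound 1 to compound 4 (0.06 log units; within the scatter), so the chloro at this position is not needed for this modest activity. Compound 4 gives a real number, and the comparisons with the two compounds held at a limit are an at least 1.7-fold lower number from compound 3 to compound 4 (0.23 log units; that floor lies within the scatter) and an at least 1.7-fold lower number from compound 2 to compound 4 (0.23 log units; that floor lies within the scatter). These are floors only, so they do not yet separate the plain phenyl from either of those groups.

On these data alone, whether an amine or a carboxylic acid at this position would move the number remains open. The step between compound 2 and compound 3 cannot be read.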